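Second Trifluoromethyl on the Benzamide Ring and Cytotoxicity

The source may report more compounds than this note shows. Statements on the series, on what has been measured and on what is new or still open speak of the compounds shown alone.

The measured compounds:
compound 1, `CCS(=O)(=O)Nc1ccc(NC(=O)c2cccc(C(F)(F)F)c2)cc1OC`, 84800 nM
compound 2, `CCS(=O)(=O)Nc1ccc(NC(=O)c2cc(C(F)(F)F)cc(C(F)(F)F)c2)cc1OC`, > 250000 nM
compound 3, `O=C(Nc1ccc(NS(=O)(=O)C(F)(F)F)c(Cl)c1)c1cccc(C(F)(F)F)c1`, 55800 nM

In an ADME assay on RAW264.7 cells (Mus musculus) for cytotoxicity, read by MTT assay, with a stated time of 48 h (on this read-out higher numbers stand for weaker inhibition and lower numbers for stronger inhibition), compound 1 gives 84800 nM. For compound 2 this assay records > 250000 nM, which is a limit rather than a number: the limit of > 250000 nM in this assay, at which 1 of the 3 values shown sits. The change from compound 1 to compound 2 is trifluoromethyl in place of hydrogen on an aromatic carbon, and it produced an at least 2.9-fold higher number from compound 1 to compound 2 (0.46 log units; beyond the scatter). Compound 3 gives 55800 nM in this assay; the difference between its core and the core of compound 1 is not broken down here, and its value lies within the scatter of that of compound 1.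

Compound 4, `O=C(Nc1ccc(NS(=O)(=O)C(F)(F)F)c(Cl)c1)c1cc(C(F)(F)F)cc(C(F)(F)F)c1`, has not yet been measured. It differs from compound 3 by trifluoromethyl in place of hydrogen on an aromatic carbon, the same structural change that separates compound 1 from compound 2. Compound 4 is therefore expected to show a step of roughly the same size, a 3.2-fold higher number from compound 3 to compound 4 (0.51 log units; beyond the scatter), because the earlier instance gave an at least 2.9-fold higher number from compound 1 to compound 2 (0.46 log units; beyond the scatter). On that basis compound 4 is estimated at 180000 nM in this assay, between 80000 nM and 300000 nM, with a fair chance that only a limit is reported.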

Compound 4, half-maximal inhibitory concentration: 136000 nM
Beside the measured number, compound 4's estimate is 1.3-fold (0.12 log units) above it; the measured number falls inside the stated range.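

In this assay, adding the second trifluoromethyl to the core of compound 3 gave a 2.4-fold higher number from compound 3 to compound 4 (0.39 log units; beyond the scatter), so the change carried over to a second core in the same direction, with both instances beyond the scatter. Set side by side, the two instances read as follows: the same change on two cores in this assay, an at least 2.9-fold higher number (0.46 log units; beyond the scatter) from compound 1 to compound 2 and a 2.4-fold higher number (0.39 log units; beyond the scatter) from compound 3 to compound 4; the limit leaves it open whether they differ. For compound 2 the record is > 250000 nM, which is a limit, and two cores establish neither an exact size for the step nor a rule for the wider series.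

The compounds shown leave open whether a different group in the same place, such as a nitrile or an amine, would shift the number in the same direction as trifluoromethyl. They also leave open whether the step would persist on a core carrying a carboxylic acid or a longer chain, and whether it would appear on any read-out other than this one.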